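Swapping a Furan for a Benzofuran on a Shared Core

The compounds below may be only part of what the source reports. "The series", "measured", "known", "first", "only" and "open" are said of these compounds alone.

Within the data shown here, the three compounds measured so far share one core and differ only in small groups attached to it. Compound 1 `COc1ncnc2c1c(-c1ccoc1)cn2[C@@H]1O[C@H](CO)[C@@H](O)[C@H]1O` is the starting point. In a functional assay on CEM-DNR-bulk cells (Homo sapiens), read by MTT assay, with a stated time of 72 h (on this read-out higher numbers stand for weaker inhibition and lower numbers for stronger inhibition), compound 1 gives > 20000 nM, which is a limit of the assay rather than a number. Compound 2 `COc1nc(N)nc2c1c(-c1ccoc1)cn2[C@@H]1O[C@H](CO)[C@@H](O)[C@H]1O` carries amino in place of hydrogen on an aromatic carbon. In this assay compound 2 gives > 20000 nM, also a limit. Compound 3 `CNc1ncnc2c1c(-c1ccoc1)cn2[C@@H]1O[C@H](CO)[C@@H](O)[C@H]1O` carries methylamino in place of methoxy on an aromatic carbon. In this assay compound 3 gives > 20000 nM, again a limit. Because of the limit of > 20000 nM in this assay, at which 3 of the 3 values shown sit, the steps a step that the two limits leave unreadable from compound 1 to compound 2 and a step that the two limits leave unreadable from compound 1 to compound 3 cannot be sized, so no measured change yet shows how far any alteration moves the inhibition.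

Compound 4 `COc1ncnc2c1c(-c1cc3ccccc3o1)cn2[C@@H]1O[C@H](CO)[C@@H](O)[C@H]1O` has not been measured; it differs from compound 1 by 1-benzofuran-2-yl in place of furan-3-yl on an aromatic carbon. Among the measured compounds shown here, no measured step touches this part of the molecule, and all three measured steps are unreadable, so there is no basis for expecting a move beyond the scatter in either direction. Compound 4 is therefore expected to stay near the limit, with an expected step of a number no higher from compound 1 to compound 4 (the limit leaves the size open). The estimate for compound 4 is 20000 nM, expected to fall between 5000 nM and 60000 nM.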

Compound 4, half-maximal inhibitory concentration: 10800 nM
For compound 4 the middle estimate is 1.9-fold (0.27 log units) above the measured one; the measured number falls inside the stated range.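

Among these compounds, compound 4 is the only one of the four compounds to give a number rather than a limit in this assay, so the position that carries the furan-3-yl group is the first place on the shared core where a change can be read at all. Putting 1-benzofuran-2-yl there, which brings in a six-membered aromatic ring of carbon only, gives an at least 1.8-fold lower number from compound 1 to compound 4 (0.26 log units; that floor lies within the scatter) and so sets only a floor: the true change may be larger, but what is secured so far does not clear the scatter. From the compounds shown here alone, the full size of the step stays open because compound 1 has no number of its own to be compared with: the limit of > 20000 nM in this assay, at which 3 of the 4 values shown sit.

The swap changes two things together, the added ring and the ring atom through which the group attaches, and a furan-2-yl or a 1-benzofuran-3-yl group at this position would be needed to pull them apart. Also open, going by these compounds, is whether a benzofuran group keeps its number when the methoxy of compound 4 gives way to an amine such as methylamino.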